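Replacing cyclopentyl with 4-methoxyphenyl in compound 1

A few compounds are considered here, and "the series" means these few. Any claim that something is new, unique, unknown or untested is made for them only; others in the source may bear on it.

Compound 1 (`Cc1cn(C2CCN(Cc3cccc(OC4CCCC4)c3)CC2)c(=O)[nH]c1=O`) gives 30300 nM
Compound 2 (`Cc1cn(C2CCN(Cc3cccc(Oc4cc(Cl)cc(Cl)c4)c3)CC2)c(=O)[nH]c1=O`) gives 6730 nM
Compound 3 (`Cc1cn(C2CCN(Cc3cccc(Oc4cccc(F)c4)c3)CC2)c(=O)[nH]c1=O`) gives > 64000 nM

In an ADME assay on MRC5 cells (Homo sapiens) for cytotoxicity, read by fluorescence and resazurin assay, with a stated time of 3 days (on this read-out higher numbers stand for weaker inhibition and lower numbers for stronger inhibition), compound 1 gives 30300 nM and holds the higher of the two exact numbers, with compound 2 nearest (6730 nM). For compound 3 the reading is a limit and not a number (> 64000 nM).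

Compound 4 (`COc1ccc(Oc2cccc(CN3CCC(n4cc(C)c(=O)[nH]c4=O)CC3)c2)cc1`) has 4-methoxyphenyl in place of cyclopentyl on an oxygen on an aromatic ring.

Two measured swaps at this place bear on the change, and they point in opposite directions: 3,5-dichlorophenyl gives a 4.5-fold lower number from compound 1 to compound 2 (0.65 log units; beyond the scatter) and 3-fluorophenyl gives an at least 2.1-fold higher number from compound 1 to compound 3 (0.32 log units; beyond the scatter). The two aryl groups also part widely from each other (an at least 9.5-fold higher number from compound 2 to compound 3 (0.97 log units; beyond the scatter)). With compound 2 and compound 3 on either side of compound 1, neither direction is favoured, so no step beyond the scatter is expected (a 1.0-fold lower number from compound 1 to compound 4 (0.00 log units; within the scatter)). Compound 4 is estimated at 30000 nM (expected range 10000 nM to 64000 nM).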

Compound 4, half-maximal inhibitory concentration: 28000 nM
Beside the measured number, compound 4's estimate is 1.1-fold (0.03 log units) above it, within the range that was stated.
By their numbers in this assay, from the lowest: compound 2; then compounds 4 and 1 (each within the scatter of the next). At a limit, above all of these: compound 3.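

In this assay, 4-methoxyphenyl takes the place of cyclopentyl on this oxygen with no step beyond the scatter (a 1.1-fold lower number from compound 1 to compound 4 (0.03 log units; within the scatter)), so among the compounds shown an aromatic ring here does not by itself set the number. The aryl groups also separate from one another, with 4-methoxyphenyl well away from 3,5-dichlorophenyl (a 4.2-fold higher number from compound 2 to compound 4 (0.62 log units; beyond the scatter)). The reading for compound 3 is a limit and not a number, so its step to the 4-methoxyphenyl group is only a bound (an at least 2.2-fold lower number from compound 3 to compound 4 (0.35 log units; beyond the scatter)).

The compounds shown leave open what a plain phenyl or a 3-chlorophenyl group on this oxygen would give, and so whether the lower number of compound 2 goes with its chlorine atoms. They also leave open whether a 3-methoxyphenyl group would read like the 4-methoxyphenyl group.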